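The compounds below may be only part of what the source reports. "The series", "measured", "known", "first", "only" and "open" are said of these compounds alone.

Measured so far:
- Compound 1, `N=C(N)NCCC[C@H](NC(=O)CN(c1nc(Cl)nc2[nH]cnc12)C1CC1)C(=O)O`: 27.6%
- Compound 2, `NC(=O)C[C@H](NC(=O)CN(c1nc(Cl)nc2[nH]cnc12)C1CC1)C(=O)O`: 20.1%
- Compound 3, `C[C@@H](O)[C@H](NC(=O)CN(c1nc(Cl)nc2[nH]cnc12)C1CC1)C(=O)O`: 35.9%

These three compounds share one core and differ only in the group on the chain carbon that sits between the amide-type nitrogen and the carbonyl carbon. In a functional assay on the whole organism (Tail, strain ICR) with Mus musculus as the target, in the tail flick test, with a stated time of 90 min, at a dose of 25 umol/kg by the oral route (a lower number here means a weaker effect, a higher number a stronger effect of the compound at the dose given), compound 3 gives the highest of the three numbers, but it is separated from compound 1 only within the scatter (a number 8.3 percentage points higher from compound 1 to compound 3 (within the scatter)), and clearly only from compound 2 (a number 15.8 percentage points higher from compound 2 to compound 3 (beyond the scatter)). Compound 1 and compound 2 lie within the scatter of each other (a number 7.5 percentage points lower from compound 1 to compound 2 (within the scatter)).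

Compound 4, `NCCCC[C@H](NC(=O)CN(c1nc(Cl)nc2[nH]cnc12)C1CC1)C(=O)O`, is not yet measured. It differs from compound 3 as follows: 4-aminobutyl in place of 1-hydroxyethyl on a saturated chain carbon bound to an amide-type nitrogen and a carbonyl carbon.

The step from compound 1 to compound 3 bears most on this change, since the group leaving in compound 4 is the one that entered there, and that step was small. The step from compound 3 to compound 4 is therefore expected to be small too, a number 7.9 percentage points lower from compound 3 to compound 4 (within the scatter), if anything downward toward compound 1. In this assay compound 4 is expected to give about 28%, in a range from 15% to 42%.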

Compound 4, a percentage reported as activity, at one dose (the size of the read-out at that dose, not a potency): 28.8%
Compound 4: the middle estimate sits 0.8 percentage points below what was measured; measured number inside the range.
By their numbers in this assay, from the lowest: compounds 2, 1, 4 and 3 (each within the scatter of the next, the first and the last beyond it).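

In this assay, 4-aminobutyl in place of 1-hydroxyethyl, on the chain carbon bound to an amide-type nitrogen and a carbonyl carbon, gives a shift that stays inside the scatter (a number 7.1 percentage points lower from compound 3 to compound 4 (within the scatter)). The other two steps are also inside it (a number 8.7 percentage points higher from compound 2 to compound 4 (within the scatter); a number 1.2 percentage points higher from compound 1 to compound 4 (within the scatter)), so compound 4 cannot be told apart from any earlier compound, even though compound 2 and compound 3 are separated beyond the scatter. No measurement shown explains these numbers.

The compounds shown leave open whether the terminal amine of 4-aminobutyl matters, which a plain butyl chain would test. Also open, as far as these compounds go, is how a carboxylic acid at the end of the chain, or a benzyl group at this carbon, would compare at this single dose and time.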